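The source may hold more compounds than are shown below. What is called first, only, known or untested is meant among the compounds shown, and "the series" means these compounds.

Working notes on the series.

Three compounds share one core and differ only in what hangs from the sulfur. In a functional assay on HT cells (Homo sapiens) for antiproliferative activity, read by fluorescence, with a stated time of 72 h (on this read-out lower numbers stand for stronger inhibition of growth and higher numbers for weaker inhibition of growth), compound 2 `CSc1nc(NCc2ccc(-c3ccccn3)cc2)c2[nH]nc(C(C)C)c2n1` gives 783 nM, the highest number of the three measured; compound 1 `CC(C)c1n[nH]c2c(NCc3ccc(-c4ccccn4)cc3)nc(SCCC(N)=O)nc12` gives 120 nM, and compound 3 `CC(C)c1n[nH]c2c(NCc3ccc(-c4ccccn4)cc3)nc(SCC(N)=O)nc12` gives 192 nM. Compound 2 is therefore the weakest growth inhibitor of the set on this read-out, with both of its steps to the others beyond the scatter.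

The next compound, compound 4 `CNCCSc1nc(NCc2ccc(-c3ccccn3)cc2)c2[nH]nc(C(C)C)c2n1`, is made from compound 2 by the change ((methylamino)methyl in place of hydrogen on a saturated chain carbon bound to a sulfur). Both measured steps out of compound 2 bear on this. Extending the chain from the sulfur gave a 4.1-fold lower number from compound 2 to compound 3 (0.61 log units; beyond the scatter) and, when read in the other direction, a 6.5-fold higher number from compound 1 to compound 2 (0.81 log units; beyond the scatter). Between compounds 1 and 3 the difference was only a 1.6-fold higher number from compound 1 to compound 3 (0.20 log units; within the scatter). Among the compounds with values here, the pattern within these three is that any chain longer than a bare methyl on the sulfur lowers the number; no compound goes against it, though only two such chains have been tried.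

Compound 4 carries a chain of comparable length with its own donor and acceptor, so a modestly lower number than compound 2 is expected, a step of about a 4.1-fold lower number from compound 2 to compound 4 (0.62 log units; beyond the scatter). The estimate for compound 4 in this assay is 190 nM, with a range from 60 nM to 600 nM.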

Compound 4, concentration for 50% growth inhibition: 56 nM
Beside the measured number, compound 4's estimate is 3.4-fold (0.53 log units) above it; measured number outside the range, below it.
By their numbers in this assay, from the lowest: compound 4; then compounds 1 and 3 (each within the scatter of the next); then compound 2.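

In this assay the position on the sulfur tolerates more than the two amide chains suggested: the 2-(methylamino)ethyl chain gives the largest step seen here (a 14-fold lower number from compound 2 to compound 4 (1.15 log units; beyond the scatter)), and compound 4 is the strongest growth inhibitor of the four, with all its steps to the others beyond the scatter. The end of the chain therefore counts as well as its presence, since methylamino in place of carbamoyl on the same chain still gives a step beyond the scatter (a 2.1-fold lower number from compound 1 to compound 4 (0.33 log units; beyond the scatter)), and the step from the shorter amide chain is of modest size (a 3.4-fold lower number from compound 3 to compound 4 (0.54 log units; beyond the scatter)), whereas the two amide chains alone could not be told apart. Nothing at hand accounts for the gain of the methylamino chain over the amide chains.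

Open, as far as these compounds go, is whether the methyl on the nitrogen matters, which a primary amine or a dimethylamino group at the end of the same chain would test. Also open, from the compounds shown here alone, is how far the chain can run and what its end must carry, which a 3-(methylamino)propyl chain and a carboxylic acid at the chain end would address.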